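The source may hold more compounds than are shown below. What is called first, only, known or untested is meant among the compounds shown, and "the series" means these compounds.

Measured so far: compound 2 `O=C(NCCCCc1ccccc1)n1c(=O)oc2cc(Cl)ccc21` with 33 nM, and compound 1 `O=C(NCCCCc1ccccc1)n1c(=O)oc2cc(-c3ccc(F)cc3)ccc21` with 79 nM.

For the measured compounds named here, in an assay on HEK293 cells for inhibition of acid ceramidase (Homo sapiens), with a stated time of 10 min (a higher number here means a weaker inhibitor, a lower number a stronger inhibitor), compound 2 holds the lower of the two numbers; the step of a 2.4-fold lower number from compound 1 to compound 2 (0.38 log units; beyond the scatter) shows how far it lies from its only neighbour. Compound 3 `O=C(c1ccc(Cl)cc1)c1ccc2c(c1)oc(=O)n2C(=O)NCCCCc1ccccc1` differs from it by (4-chlorophenyl)carbonyl in place of chloro on an aromatic carbon. Going by the values given here, the one step known runs the other way, an aryl group giving way to chloro, and it was modest. Putting an aryl group back, here a (4-chlorophenyl)carbonyl, is therefore expected to raise the number by a similar, modest amount, a 2.1-fold higher number from compound 2 to compound 3 (0.33 log units; beyond the scatter). Compound 3 is estimated at 70 nM, within 25 nM to 200 nM.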

Compound 3, half-maximal inhibitory concentration: 14 nM
Compound 3: the middle estimate sits 5.0-fold (0.70 log units) above what was measured; the whole stated range lies above it.
By their numbers in this assay, from the lowest: compound 3; then compound 2; then compound 1.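

At this position, an added aromatic ring does not by itself raise the number: with (4-chlorophenyl)carbonyl in place of chloro, this assay shows a 2.4-fold lower number from compound 2 to compound 3 (0.37 log units; beyond the scatter). Replacing 4-fluorophenyl with the same group gives a 5.6-fold lower number from compound 1 to compound 3 (0.75 log units; beyond the scatter), so the two ring-bearing substituents lie at opposite ends of the three values, with the chloro compound between them. Nothing available explains this order.

From the compounds shown here alone, it remains open whether the carbonyl or the chlorine of the entering group matters more. An unsubstituted benzoyl group, a methoxy group or an amine at this carbon would help to separate these contributions.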